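Matrilysin inhibitors: a glycine-for-asparagine exchange in a sulfonamide peptide

This account rests on a few compounds, and the source may have more. Where it says the series, first, only, none or still open, it means among the compounds named here.

Compound 1: `CC(C)C[C@H](NC(=O)CNC(=O)CC[C@H](NS(=O)(=O)c1ccc(Cl)c(C(F)(F)F)c1)C(=O)O)C(=O)N[C@H](C(=O)N[C@@H](C)C(N)=O)C(C)C` — 16 nM
Compound 2: `CSCC[C@H](NC(=O)[C@H](CC(C)C)NC(=O)[C@H](CC(N)=O)NC(=O)CC[C@H](NS(=O)(=O)c1ccc(Cl)c(C(F)(F)F)c1)C(=O)O)C(N)=O` — 7500 nM

Of the compounds shown here, two have been measured in an assay on isolated protein for inhibition of Matrilysin (Homo sapiens), read by fluorescence, with a stated time of 15 min; a higher number here means a weaker inhibitor, a lower number a stronger inhibitor. Compound 1 gives 16 nM in this assay, while compound 2 gives 7500 nM, the higher of the two numbers and far beyond the scatter from compound 1. Among the compounds with values here, the two differ in more than one place, so no single step between them can be read off.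

Compound 3, `CSCC[C@H](NC(=O)[C@H](CC(C)C)NC(=O)CNC(=O)CC[C@H](NS(=O)(=O)c1ccc(Cl)c(C(F)(F)F)c1)C(=O)O)C(N)=O`, is not yet measured. It is made from compound 2 by hydrogen in place of carbamoylmethyl on a saturated chain carbon bound to an amide-type nitrogen and a carbonyl carbon, which brings that position into line with compound 1 while keeping the rest of compound 2. Within the data shown here, no measured pair shows this step on its own, so its size and direction cannot be taken from the data. A move toward compound 1 seems plausible but is uncertain; a step of a 5.0-fold lower number from compound 2 to compound 3 (0.70 log units; beyond the scatter) is expected. Compound 3 is estimated at 1500 nM, within a range of 150 nM to 8000 nM.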

Compound 3, half-maximal inhibitory concentration: 120 nM
Compound 3: the middle estimate sits 13-fold (1.10 log units) above what was measured, outside the stated range (below it).
By their numbers in this assay, from the lowest: compound 1; then compound 3; then compound 2.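

In this assay, hydrogen in place of carbamoylmethyl on a saturated chain carbon bound to an amide-type nitrogen and a carbonyl carbon gives a 63-fold lower number from compound 2 to compound 3 (1.80 log units; beyond the scatter), a large step that shows this one position alone has a strong bearing on the read-out. The other change is smaller: 1-carbamoyl-3-(methylsulfanyl)propyl in place of 1-((1-carbamoylethyl)carbamoyl)-2-methylpropyl on an amide-type nitrogen gives a 7.5-fold higher number from compound 1 to compound 3 (0.88 log units; beyond the scatter), a modest step by comparison. Nothing available explains why either change has the size it does.

On these data alone, it remains open whether a methyl, a hydroxymethyl or a carboxymethyl group on this carbon would behave more like hydrogen or like carbamoylmethyl. As far as these compounds go, it is also open whether carbamoylmethyl would have a step of similar size on the longer chain of compound 1.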